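Working notes: dimethylamino variant of compound 1

The source may report more compounds than this note shows. Statements on the series, on what has been measured and on what is new or still open speak of the compounds shown alone.

Compound 1 `COc1ccc(C2CC(c3ccccc3)=NN2C2=NC(=O)/C(=C3\C(=O)Nc4ccc(Br)cc43)S2)cc1` carries a methoxy on one aryl group and an unsubstituted phenyl on the carbon with a double bond to nitrogen; in a functional assay on cells (Cancer cell lines, Homo sapiens) for cytotoxicity, read by sulforhodamine B assay, with a stated time of 48 h (on this read-out higher numbers stand for weaker inhibition of growth and lower numbers for stronger inhibition of growth), compound 1 gives 200 nM. Compound 2 `COc1ccc(C2=NN(C3=NC(=O)/C(=C4\C(=O)Nc5ccc(Br)cc54)S3)C(c3ccc(OC)cc3)C2)cc1` adds a second methoxy, and compound 2 gives 200 nM, so that no change at the digits printed from compound 1 to compound 2 (within the scatter). Compound 3 `COc1ccc(C2CC(c3ccc4ccccc4c3)=NN2C2=NC(=O)/C(=C3\C(=O)Nc4ccc(Br)cc43)S2)cc1` puts naphthalen-2-yl in place of the phenyl; compound 3 gives 54 nM, and a 3.7-fold lower number from compound 1 to compound 3 (0.57 log units; beyond the scatter). On these numbers compound 1 stands level with compound 2, together the highest of the three, while compound 3 gives the lower number.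

Compound 4 `CN(C)c1ccc(C2CC(c3ccccc3)=NN2C2=NC(=O)/C(=C3\C(=O)Nc4ccc(Br)cc43)S2)cc1` differs from compound 1 by dimethylamino in place of methoxy on an aromatic carbon, that is, 4-methoxyphenyl becomes 4-(dimethylamino)phenyl. For the measured compounds named here, no measured step touches this substituent: the step from compound 1 to compound 2 only adds a methoxy elsewhere without moving the number, and the step from compound 1 to compound 3 concerns the other aryl group, where a larger ring gave a modest gain. Going by the values given here, the change here is small and the one comparable small change left the number flat, so in this assay compound 4 is expected to show no change at the digits printed from compound 1 to compound 4 (within the scatter), no step beyond the scatter. The estimate for compound 4 is 200 nM, with a range from 80 nM to 500 nM.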

Compound 4, concentration for 50% growth inhibition: 220 nM
Compound 4: middle estimate off by 1.1-fold (0.04 log units), on the low side; the range from low to high includes it.
By their numbers in this assay, from the lowest: compound 3; then compounds 1, 2 and 4 (each within the scatter of the next).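

For the compounds shown here, the step from 4-methoxyphenyl to 4-(dimethylamino)phenyl is the first measured change at this substituent, and in this assay it gives a 1.1-fold higher number from compound 1 to compound 4 (0.04 log units; within the scatter). On this aromatic carbon, therefore, methoxy and dimethylamino read alike, and the exchange of one oxygen-linked group for a nitrogen-linked group with one more heavy atom leaves the number within the scatter, whereas the step beyond the scatter remains the one at the other aryl group, a 3.7-fold lower number from compound 1 to compound 3 (0.57 log units; beyond the scatter). No supporting measurement is available to explain why these two groups read alike.

From the compounds shown here alone, two groups on this carbon give only a narrow view of it, so it remains open whether a carboxylic acid, a primary amine or a longer chain such as butoxy would also stay within the scatter of compound 1. Also open, going by these compounds, is whether the same exchange of methoxy for dimethylamino would stay as flat on the naphthalen-2-yl background of compound 3, which gives 54 nM, since the present step was read only with the unsubstituted phenyl in place.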